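The compounds below may be only part of what the source reports. "The series", "measured", "known", "first", "only" and "open" are said of these compounds alone.

Values in a functional assay on HepG2 cells (Homo sapiens) for inhibition, read by MTT assay, with a stated time of 72 h (a lower number here means a stronger inhibitor, a higher number a weaker inhibitor), for the measured members of the series:

compound 1 `N#Cc1ccccc1-n1cc(COc2cccc(NC(=O)Nc3ccc(Cl)c(C(F)(F)F)c3)c2)nn1` gives 1970 nM
compound 2 `N#Cc1ccc(-n2cc(COc3cccc(NC(=O)Nc4ccc(Cl)c(C(F)(F)F)c4)c3)nn2)cc1` gives 2980 nM
compound 3 `O=C(Nc1cccc(OCc2cn(-c3cccc(F)c3)nn2)c1)Nc1ccc(Cl)c(C(F)(F)F)c1` gives 2120 nM

Compound 3 sits second highest of the three numbers. Its nearest neighbour is compound 1, a 1.1-fold higher number from compound 1 to compound 3 (0.03 log units; within the scatter); its furthest is compound 2, a 1.4-fold lower number from compound 2 to compound 3 (0.15 log units; within the scatter). Both gaps lie within the scatter, so the three compounds cannot be ordered against each other.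

Compound 4 `O=C(Nc1cccc(OCc2cn(-c3cccc(Br)c3)nn2)c1)Nc1ccc(Cl)c(C(F)(F)F)c1` is not yet measured. The change from compound 3 is bromo in place of fluoro on an aromatic carbon. Going by the values given here, the steps that bear on it are those that vary the aryl group on the aromatic nitrogen of the shared core: a 1.5-fold higher number from compound 1 to compound 2 (0.18 log units; within the scatter), a 1.1-fold higher number from compound 1 to compound 3 (0.03 log units; within the scatter) and a 1.4-fold lower number from compound 2 to compound 3 (0.15 log units; within the scatter), all within the scatter. Among the compounds with values here, none of the measured steps swaps one halogen for another, so the expectation rests only on the observation that exchanges at this position have moved nothing beyond the scatter. The expected step is therefore a 1.0-fold lower number from compound 3 to compound 4 (0.00 log units; within the scatter), no direction beyond the scatter. Compound 4 is estimated at 2100 nM, with a range from 900 nM to 4800 nM.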

Compound 4, half-maximal inhibitory concentration: 1040 nM
The estimate for compound 4 lay 2.0-fold (0.31 log units) above the measured number, and the stated range covers the measured number.
By their numbers in this assay, from the lowest: compounds 4, 1, 3 and 2 (each within the scatter of the next, the first and the last beyond it).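

In this assay the halogen exchange gives a 2.0-fold lower number from compound 3 to compound 4 (0.31 log units; beyond the scatter) and is the first step among these aryl groups on the aromatic nitrogen to pass beyond the scatter, so this position is not as flat as the earlier compounds suggested. Set against the nitrile-bearing aryl groups, 3-bromophenyl gives a 2.9-fold lower number from compound 2 to compound 4 (0.46 log units; beyond the scatter) but only a 1.9-fold lower number from compound 1 to compound 4 (0.28 log units; within the scatter) and therefore separates from 4-cyanophenyl but not from 2-cyanophenyl. No supporting data bear on why bromo and fluoro differ here.

The compounds shown leave open whether chloro, iodo, methyl or methoxy at this carbon would read closer to bromo or to fluoro. They also leave open whether bromo on another carbon of the same ring, or an amine or carboxylic acid in its place, would keep this step.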